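Furan for thiophene on the saturated ring carbon

The source may hold more compounds than are shown below. What is called first, only, known or untested is meant among the compounds shown, and "the series" means these compounds.

Two compounds of this spiro series have a value in a functional assay on the whole organism (strain Wister albino) for inhibition, with Rattus norvegicus as the target, read by paw edema, with stated times of 1 h and 2 h, at a dose of 50 mg/kg by the intraperitoneal route; on this read-out lower numbers stand for less inhibition and higher numbers for more inhibition at the one dose given (going by the name of the read-out). Compound 1 `CN1C(=O)[C@@]2(c3ccccc31)N(C)C[C@@H](c1ccco1)[C@@]21Cc2ccccc2C1=O` gives 33.1%. Compound 2 `CN1C[C@@H](c2cccs2)[C@@]2(Cc3ccccc3C2=O)[C@@]12C(=O)Nc1ccccc12` gives 39.1%, a number that sits within the scatter of compound 1, so no order between the two can be read. Compound 3 `CN1C[C@@H](c2ccco2)[C@@]2(Cc3ccccc3C2=O)[C@@]12C(=O)Nc1ccccc12` differs from compound 2 only by furan-2-yl in place of thiophen-2-yl on a saturated ring carbon. Among the measured compounds shown here, no measured pair shows this change on its own, so the expected step of a number 2.1 percentage points lower from compound 2 to compound 3 (within the scatter) is taken as none beyond the scatter. Compound 3 is therefore estimated at 37%, within 26% to 48%.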

Compound 3, a percentage reported as inhibition, in the whole organism at one dose (the size of the read-out at that dose, not a potency): 53.6%
Beside the measured number, compound 3's estimate is 16.6 percentage points below it; the whole stated range lies below it.
By their numbers in this assay, from the lowest: compounds 1 and 2 (each within the scatter of the next); then compound 3.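

In this assay, the saturated ring carbon responds to the ring it carries: furan-2-yl in place of thiophen-2-yl gives a number 14.5 percentage points higher from compound 2 to compound 3 (beyond the scatter). The amide-type nitrogen in the ring also responds, with hydrogen in place of methyl giving a number 20.5 percentage points higher from compound 1 to compound 3 (beyond the scatter), so compound 3, which holds both furan-2-yl and the amide hydrogen, stands above the other two. Nothing at hand bears on why either step occurs.

Open, on these data alone, is how an amine or a phenyl ring on the saturated ring carbon would read. As far as these compounds go, an ethyl group on the amide-type nitrogen is equally open, and a single dose leaves potency unread.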